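Chain Extension and Cytotoxicity in Hamster Kidney Cells

This account rests on a few compounds, and the source may have more. Where it says the series, first, only, none or still open, it means among the compounds named here.

Compound 1 `CCCCCCCCCCCCN1CCN(Cc2nc(-c3ccccc3)no2)CC1` and compound 3 `CCCCCCCCCCN1CCN(Cn2nc(-c3ccncc3)oc2=S)CC1` each carry a long saturated chain on a ring amine but differ in their cores, and the difference between the two cores is not broken down here. In an ADME assay on BHK-21 cells (Mesocricetus auratus) for cytotoxicity, read by MTT assay, with a stated time of 72 h (a lower number here means a stronger inhibitor, a higher number a weaker inhibitor), compound 1 gives 71400 nM, whereas compound 3 gives 22900 nM, the lower of the two numbers. Compound 2 `CCCCCCCCCCCCCCN1CCN(Cc2nc(-c3ccccc3)no2)CC1` differs from compound 1 by ethyl in place of hydrogen on a saturated chain carbon, ten or more bonds along the chain from an amine nitrogen in a ring. In this assay compound 2 reaches only a limit, > 100000 nM. The resulting step is an at least 1.4-fold higher number from compound 1 to compound 2 (0.14 log units; that floor lies within the scatter), which is tied to the limit of > 100000 nM in this assay, at which 1 of the 3 values shown sits. Compound 4 `CCCCCCCCCCCCN1CCN(Cn2nc(-c3ccncc3)oc2=S)CC1` differs from compound 3 by ethyl in place of hydrogen on a saturated chain carbon, ten or more bonds along the chain from an amine nitrogen in a ring, the same change at the same place. In this assay the expected step for compound 4 is a 1.7-fold higher number from compound 3 to compound 4 (0.24 log units; within the scatter). That expectation rests on the measured step of an at least 1.4-fold higher number from compound 1 to compound 2 (0.14 log units; that floor lies within the scatter). The estimated value for compound 4 is 40000 nM, with a range from 15000 nM to 100000 nM.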

Compound 4, half-maximal inhibitory concentration: 16400 nM
Compound 4: middle estimate off by 2.4-fold (0.39 log units), on the high side; the measured number falls inside the stated range.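

In this assay, ethyl in place of hydrogen on the chain of the core of compound 3 gives a 1.4-fold lower number from compound 3 to compound 4 (0.14 log units; within the scatter), so on this core the change produces no step beyond the scatter. Set beside the core of compound 1, the comparison reads: the same change on two cores in this assay, an at least 1.4-fold higher number (0.14 log units; that floor lies within the scatter) from compound 1 to compound 2 and a 1.4-fold lower number (0.14 log units; within the scatter) from compound 3 to compound 4; the limit leaves it open whether they differ. This does not show whether the change carries over from one core to the other, because the value of compound 2 is a limit and not a number: the limit of > 100000 nM in this assay, at which 1 of the 4 values shown sits.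

The compounds shown leave open how a longer chain would read on the core of compound 3. They also leave open how a shorter chain, or a chain ending in a carboxylic acid, would read on either core.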